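From Propoxy to Benzyloxy: Expecting a Modest Rise

This account rests on a few compounds, and the source may have more. Where it says the series, first, only, none or still open, it means among the compounds named here.

Within the data shown here, compound 2 `CCCOC(=O)C1=C(C)N(C)C(=O)NC1c1ccoc1` stands lowest of the two compounds measured so far: in an assay on membranes from CHO cells for displacement of a labelled ligand from adenosine receptor A1 (Homo sapiens), read by scintillation counting, with a stated time of 60 min, tested at 1 uM (a lower number here means less inhibition, a higher number more inhibition at the concentration tested (going by the name of the read-out)), compound 2 gives 1%, while compound 1 `CC1=C(C(=O)OCc2ccccc2)C(c2ccoc2)NC(=O)N1` gives 41%, a gap beyond the usual scatter. Compound 3 `CC1=C(C(=O)OCc2ccccc2)C(c2ccoc2)NC(=O)N1C` has not yet been measured. It differs from compound 2 by phenyl in place of ethyl on a saturated chain carbon bound to an oxygen next to a carbonyl group. Compound 1 also carries benzyloxy, but it differs from compound 3 in another place as well, so its value is only a hint. An upward step from compound 2 to compound 3 of a number 17 percentage points higher from compound 2 to compound 3 (beyond the scatter) is expected. Compound 3 is estimated at 18%, within 0% to 40%.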

Compound 3, a percentage reported as inhibition, at one concentration (the size of the read-out at that concentration, not a potency): 51%
For compound 3 the middle estimate is 33 percentage points below the measured one, outside the stated range (above it).
By their numbers in this assay, from the lowest: compound 2; then compounds 1 and 3 (each within the scatter of the next).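

In this assay, among these compounds, the change from propoxy to benzyloxy brings a large rise (a number 50 percentage points higher from compound 2 to compound 3 (beyond the scatter)), giving the first comparison at this position that differs in one place only. With benzyloxy present, methyl in place of hydrogen on the amide-type nitrogen in a ring makes no clear difference (a number 10 percentage points higher from compound 1 to compound 3 (within the scatter)). Nothing available explains the rise. The compounds shown leave open whether the gain depends on the aromatic ring or simply on a larger group. A cyclohexyl group or a longer chain such as butyl in that place would help separate the two.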